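Nitro position shift in a dienone series

A few compounds are considered here, and "the series" means these few. Any claim that something is new, unique, unknown or untested is made for them only; others in the source may bear on it.

Compound 1 `COc1cc(/C=C2\CCC/C(=C\c3cccc([N+](=O)[O-])c3)C2=O)cc(OC)c1OC` and compound 3 `CN(C)c1ccc(/C=C2\CCC/C(=C\c3cccc([N+](=O)[O-])c3)C2=O)cc1` both carry a 3-nitrophenyl group on different cores; the difference between the two cores is not broken down here. In a functional assay on L1210 cells (Mus musculus) for cytotoxicity, with a stated time of 48 h (on this read-out higher numbers stand for weaker inhibition and lower numbers for stronger inhibition), compound 1 gives 42200 nM, and compound 3 gives 156000 nM. Compound 2 `CN(C)c1ccc(/C=C2\CCC/C(=C\c3ccc([N+](=O)[O-])cc3)C2=O)cc1` is made from compound 3 by the change (4-nitrophenyl in place of 3-nitrophenyl on a double-bonded chain carbon bound to a double-bonded ring carbon). For compound 2 the result is a limit of the assay, > 500000 nM (the limit of > 500000 nM in this assay, at which 1 of the 3 values shown sits). That change produced an at least 3.2-fold higher number from compound 3 to compound 2 (0.50 log units; beyond the scatter). Compound 4 `COc1cc(/C=C2\CCC/C(=C\c3ccc([N+](=O)[O-])cc3)C2=O)cc(OC)c1OC` is obtained from compound 1 by the same change, (4-nitrophenyl in place of 3-nitrophenyl on a double-bonded chain carbon bound to a double-bonded ring carbon), on the core of compound 1. Among the compounds with values here, only one measured pair carries this change, and it ends at a limit, so its full size is not fixed. Because compound 3 gives 156000 nM and the change gave an at least 3.2-fold higher number from compound 3 to compound 2 (0.50 log units; beyond the scatter), a comparable weakening is expected for compound 4, estimated as a 3.6-fold higher number from compound 1 to compound 4 (0.55 log units; beyond the scatter). Compound 4 is therefore estimated at 150000 nM, expected to fall between 60000 nM and 450000 nM.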

Compound 4, half-maximal inhibitory concentration in the L1210 assay: 6970 nM
For compound 4 the middle estimate is 22-fold (1.33 log units) above the measured one; measured number below the stated range.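

In the L1210 assay compound 4 gives 6970 nM. In the L1210 assay, 4-nitrophenyl in place of 3-nitrophenyl gives a 6.1-fold lower number from compound 1 to compound 4 (0.78 log units; beyond the scatter), opposite in direction to the step on the core of compound 3, so neither the size nor the direction of the step carries from one core to the other: the same change on two cores in the L1210 assay, an at least 3.2-fold higher number (0.50 log units; beyond the scatter) from compound 3 to compound 2 and a 6.1-fold lower number (0.78 log units; beyond the scatter) from compound 1 to compound 4, at least 19-fold (1.28 log units) apart, beyond the scatter of two such steps Compound 2 stands at > 500000 nM, which is a limit of the assay, so the step on that core has a direction but no fixed size. The two pairs show that the outcome of this change depends on the core in this series, but they do not show which part of the core decides it, and in a physicochemical assay for lipophilicity (on this read-out lower numbers stand for lower lipophilicity and higher numbers for higher lipophilicity), the pair on the core of compound 1 reads a number 0.02 log units higher from compound 1 to compound 4 (within the scatter). In the physicochemical assay compound 1 gives 5.06, and compound 4 gives 5.08.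

Two cores cannot say which direction is the more usual one on further cores. Also open, from the compounds shown here alone, is whether a nitrile or a carboxylic acid in place of the nitro group would show the same dependence on the core.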